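This account rests on a few compounds, and the source may have more. Where it says the series, first, only, none or still open, it means among the compounds named here.

In a functional assay on PC-3 cells (Homo sapiens) for inhibition, read by sulforhodamine B assay, with a stated time of 48 h, tested at 50 uM (on this read-out lower numbers stand for less inhibition of growth and higher numbers for more inhibition of growth at the one concentration tested), two compounds have been measured so far. Compound 1 (`COc1cc(/C=C/C(=O)/C=C/c2ccco2)ccc1OCc1cn(CCCOc2cc(=O)oc3ccccc23)nn1`) is reported as "not active" (no number reported), with no number attached. Among the measured compounds shown here, compound 2 (`COc1cc(/C=C/C(=O)/C=C/c2cccs2)ccc1OCc1cn(CCOc2cc(=O)oc3ccccc23)nn1`) gives 12%, the only number available, so it cannot yet be ranked numerically against another compound. Compound 3 (`COc1cc(/C=C/C(=O)/C=C/c2cc(OC)c(OC)c(OC)c2)ccc1OCc1cn(CCOc2cc(=O)oc3ccccc23)nn1`) differs from compound 2 in one place: 3,4,5-trimethoxyphenyl in place of thiophen-2-yl on a double-bonded chain carbon bound to a double-bonded chain carbon. This puts 3,4,5-trimethoxyphenyl in place of thiophen-2-yl on a double-bonded chain carbon bound to a double-bonded chain carbon. For the measured compounds named here, no measured pair isolates this change, since compound 1 and compound 2 differ in more than one place. With compound 2 at 12%, the read-out leaves more room upward than downward, so a modest rise is expected. The expected change in this assay is a number 8 percentage points higher from compound 2 to compound 3 (within the scatter), an uncertain estimate. Compound 3 is estimated at 20%, with an expected range from 5% to 45%.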

Compound 3, percent growth inhibition at one concentration: 22%
Compound 3: the middle estimate sits 2 percentage points below what was measured; the range from low to high includes it.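

In this assay the first pair differing in one place, 3,4,5-trimethoxyphenyl in place of thiophen-2-yl on a double-bonded chain carbon bound to a double-bonded chain carbon, gives a number 10 percentage points higher from compound 2 to compound 3 (within the scatter) and so shows no change that can be told from the scatter. This position therefore carries a six-membered aromatic ring of carbon only, with 12 heavy atoms and 3 hydrogen-bond acceptors, as well as a five-membered aromatic ring with 5 heavy atoms, and the read-out stays at the same level. No measurement at hand offers an explanation for this outcome.

Going by these compounds, what an amine or a carboxylic acid in this place would give in this assay remains open. Compound 1 differs from compound 2 in more than one place, so the effect of a longer chain on the triazole nitrogen cannot be read from it.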